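The source may hold more compounds than are shown below. What is called first, only, known or untested is meant among the compounds shown, and "the series" means these compounds.

Measured compounds:
compound 1, `CC1=C(N2CC2)C(=O)C(CC(C)OC(N)=O)=C(N2CC2)C1=O`, 5.79
compound 2, `CCC(COC(N)=O)C1=C(N2CC2)C(=O)C(C)=C(N2CC2)C1=O`, 5.66

Of the compounds shown here, two have been tested in a functional assay on L1210 cells (Mus musculus), with a stated time of 12 days; on this read-out higher numbers stand for higher potency (the scale is a negative logarithm) and lower numbers for lower potency. Compound 1 gives 5.79, and compound 2 gives 5.66. These two numbers lie within the usual scatter of each other, so neither compound can be placed above the other; compound 2 simply stands level with compound 1 on this read-out.

Compound 3, `CCC(OC)C1=C(N2CC2)C(=O)C(C)=C(N2CC2)C1=O`, has not yet been tested. It differs from compound 2 in one place: methoxy in place of (carbamoyloxy)methyl on a saturated chain carbon bound to a double-bonded ring carbon and a saturated chain carbon. The group that leaves carries a hydrogen-bond donor and two acceptors; the group that enters is smaller and carries a single acceptor. Among the compounds with values here, no step between measured compounds shows what such a change does here, so the direction can only be guessed. A modest loss is expected, so that compound 3 is estimated at 5.35 in this assay, within 4.85 to 5.85, meaning an expected step of a number 0.31 log units lower from compound 2 to compound 3 (beyond the scatter).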

Compound 3, logarithm of the reciprocal of the active concentration, log(1/C): 5.33
For compound 3 the middle estimate is 0.02 log units above the measured one, and the stated range covers the measured number.
By their numbers in this assay, from the lowest: compound 3; then compounds 2 and 1 (each within the scatter of the next).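

In this assay, methoxy in place of (carbamoyloxy)methyl on a saturated chain carbon bound to a double-bonded ring carbon and a saturated chain carbon gives a number 0.33 log units lower from compound 2 to compound 3 (beyond the scatter), so the group held at this carbon does register on this read-out. The second comparison, a group of 5 heavy atoms in place of a group of 7 heavy atoms on a double-bonded ring carbon, gives a number 0.46 log units lower from compound 1 to compound 3 (beyond the scatter) and points the same way. Nothing available here explains either fall.

These compounds cannot separate the loss of the carbamoyloxy part from the shortening of the group as a whole, since both happen in the same change. A hydroxymethyl group or a methoxymethyl group on the same saturated chain carbon would pull these two apart.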